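Hydroxy for Methyl at the Chain End of Compound 3

The source may report more compounds than this note shows. Statements on the series, on what has been measured and on what is new or still open speak of the compounds shown alone.

Compound 3 `Cc1ccccc1CCCCCC(=O)N1CCOC1=O` was tested in an assay on HEK293 cells for inhibition of N-acylethanolamine-hydrolyzing acid amidase (Rattus norvegicus), read by LC-MS, with a stated time of 30 min; a higher number here means a weaker inhibitor, a lower number a stronger inhibitor. In this assay compound 3 gives only a limit of the assay, > 20000 nM. Compound 1 `O=C(O)c1ccc(CCCCCC(=O)N2CCOC2=O)cc1` likewise gives only a limit in this assay, > 20000 nM. Compound 2 `CCCCCCOc1ccc(C(=O)N2CCOC2=O)cc1` gives a number in this assay, 640 nM. So compound 3 sits at the limit of > 20000 nM in this assay, at which 2 of the 3 values shown sit, shared with one other compound. Compound 4 `O=C(CCCCCc1ccccc1O)N1CCOC1=O` has not yet been measured. It differs from compound 3 in one place: hydroxy in place of methyl on an aromatic carbon. Within the data shown here, no measured pair covers this change, so the expectation rests on compound 3 alone, and the change is expected to bring at most a small gain, near the scatter, with a fair chance that compound 4 also ends at a limit. Compound 4 is expected to give about 15000 nM, between 3000 nM and 60000 nM. The expected step is an at least 1.3-fold lower number from compound 3 to compound 4 (0.12 log units; that floor lies within the scatter).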

Compound 4, half-maximal inhibitory concentration: > 20000 nM
Compound 4: no number, only a limit; the forecaster's own chance of this, stated with the estimate: 55%; middle value at least 1.3-fold (0.12 log units) away from the limit.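

Among these compounds, compound 3 and compound 4 both end at a limit of the assay, so no step between them can be read. From the compounds shown here alone, whether hydroxy in place of methyl changes inhibition at all remains open.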